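This account rests on a few compounds, and the source may have more. Where it says the series, first, only, none or still open, it means among the compounds named here.

In a functional assay on PC-3 cells (Homo sapiens) for inhibition, read by sulforhodamine B assay, with a stated time of 48 h (a lower number here means a stronger inhibitor, a higher number a weaker inhibitor), the measured compounds stand as follows. Compound 1 `COC(=O)[C@@]1(C)C[C@@H](c2coc3ccc(Br)cc3c2=O)N(c2ccccc2)O1` gives > 60000 nM, which is a limit of the assay. Compound 2 `CCO[C@H]1C[C@@H](c2coc3cc(Cl)c(Cl)cc3c2=O)N(c2ccccc2)O1` likewise gives a limit, > 60000 nM. Compound 3 `COC(=O)[C@@]1(C)C[C@@H](c2coc3ccc(F)cc3c2=O)N(c2ccccc2)O1` gives 31300 nM.

Among the measured compounds shown here, compound 3 therefore holds the only number among the three; the other two values are limits, sitting at the limit of > 60000 nM in this assay, at which 2 of the 3 values shown sit. Compound 4 `COC(=O)[C@@]1(C)C[C@@H](c2coc3ccc(C)cc3c2=O)N(c2ccccc2)O1` differs from compound 3 by methyl in place of fluoro on an aromatic carbon. For the measured compounds named here, the single measured step at this position, an at least 1.9-fold lower number from compound 1 to compound 3 (0.28 log units; that floor lies within the scatter), reached only the edge of the scatter, so no change beyond the scatter is expected in this assay for compound 4. Compound 4 is expected to give about 45000 nM, within a range of 15000 nM to 150000 nM. The expected step is a 1.4-fold higher number from compound 3 to compound 4 (0.16 log units; within the scatter), with a real chance that only a limit is reported.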

Compound 4, half-maximal inhibitory concentration: > 60000 nM
Compound 4 ended at the assay's limit; the forecaster's own chance of this, stated with the estimate: 45%; at least 1.3-fold (0.12 log units) between middle value and limit.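

Methyl in place of fluoro on this aromatic carbon gives an at least 1.9-fold higher number from compound 3 to compound 4 (0.28 log units; that floor lies within the scatter), so in this assay methyl joins bromo in leaving no readable number, and the step between those two, from limit to limit, cannot be read. Among these compounds, only the fluoro compound 3 keeps a number, while the others share one limit: the limit of > 60000 nM in this assay, at which 3 of the 4 values shown sit.

Going by these compounds, whether a methoxy group, an amine or a carboxylic acid on this aromatic carbon would give a number remains open. So does whether any group here could produce a step beyond the scatter.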